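The source may report more compounds than this note shows. Statements on the series, on what has been measured and on what is new or still open speak of the compounds shown alone.

Compound 2 `COc1ccc(-c2ccc(OCc3cc(C(=O)NS(=O)(=O)c4ccc(C)cn4)oc3C)cc2)cc1` gives the lowest of the two numbers in an assay on cells for displacement of a labelled ligand from prostaglandin E2 receptor EP4 subtype (Homo sapiens), read by scintillation counting (on this read-out higher numbers stand for weaker inhibition and lower numbers for stronger inhibition), at 15 nM. For the measured compounds named here, compound 1 `COc1ccc(-c2ccc(OCc3cc(C(=O)NS(=O)(=O)c4ccc(CN)cc4)oc3C)cc2)cc1` gives 100 nM, and a 6.7-fold lower number from compound 1 to compound 2 (0.82 log units; beyond the scatter) was the only measured step. Compound 3 `COc1ccc(-c2ccc(OCc3cc(C(=O)NS(=O)(=O)c4ccccc4)oc3C)cc2)cc1` differs from compound 2 by phenyl in place of 5-methylpyridin-2-yl on a sulfonyl sulfur. Going by the values given here, the one measured step bears on it only loosely, since it replaced the whole group on the sulfonyl sulfur; that group clearly matters, so a modest weakening is expected. Compound 3 is estimated at 40 nM, within a range from 12 nM to 130 nM. That expectation means a step of a 2.7-fold higher number from compound 2 to compound 3 (0.43 log units; beyond the scatter).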

Compound 3, inhibition constant: 5 nM
Estimate against measurement, compound 3: 8.0-fold (0.90 log units) above, and the stated range ends above it.
By their numbers in this assay, from the lowest: compound 3; then compound 2; then compound 1.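

Phenyl on the sulfonyl sulfur gives stronger inhibition than 5-methylpyridin-2-yl, with a 3.0-fold lower number from compound 2 to compound 3 (0.48 log units; beyond the scatter) for this swap. The bare ring therefore needs neither the ring nitrogen nor the methyl to do well. Hydrogen in place of aminomethyl on an aromatic carbon gives a 20-fold lower number from compound 1 to compound 3 (1.30 log units; beyond the scatter) and is the largest step so far, so the aminomethyl group is clearly not needed either.

The swap from 5-methylpyridin-2-yl changes two features at once, which leaves open how much each contributes, and how fluorine or a carboxylic acid on the phenyl ring would fare is also unknown. No measured evidence here accounts for these steps.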